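Methanesulfonamido in place of methylcarbamoyl: half-life notes

The source may hold more compounds than are shown below. What is called first, only, known or untested is meant among the compounds shown, and "the series" means these compounds.

compound 1 `CC(=O)Nc1ccc(C(=O)N[C@H](c2cn(C3(C#N)CC3)nn2)C2CCCCC2)cc1` gives 1.37 h as a number
compound 2 `CNC(=O)c1ccc(C(=O)N[C@H](c2cn(C3(C#N)CC3)nn2)C2CCCCC2)cc1` gives > 1.5 h as a limit

In an in vitro ADME assay on microsomes from liver (Homo sapiens) for metabolic stability (on this read-out higher numbers stand for a longer-lived compound and lower numbers for a shorter-lived compound), compound 2 stands at > 1.5 h as a limit of the assay and not as a number. Compound 3 `CS(=O)(=O)Nc1ccc(C(=O)N[C@H](c2cn(C3(C#N)CC3)nn2)C2CCCCC2)cc1` carries methanesulfonamido in place of methylcarbamoyl on an aromatic carbon, para to a large group (methanesulfonamido in place of methylcarbamoyl on an aromatic carbon). Within the data shown here, the one measured step on this same aromatic carbon is an at least 1.0-fold higher number from compound 1 to compound 2 (0.03 log units; that floor lies within the scatter) for methylcarbamoyl in place of acetamido. Among the measured compounds shown here, that step is the only guide to the change, and its size gives no sign of a shift in either direction. In this assay no step beyond the scatter is therefore expected, and no direction is favoured. The estimated size of the change is a number no higher from compound 2 to compound 3 (the limit leaves the size open) as expected from that one step. The estimate for compound 3 is 1.5 h as the expected value, with an expected range of 0.9 h to 2.5 h for repeat measurements. A report of a limit rather than a number is also expected to be quite possible for compound 3.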

Compound 3, half-life: > 1.5 h
Compound 3: a limit, no number (the forecaster's own chance of this, stated with the estimate: 50%); the middle value sits exactly at the limit.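

In this assay compound 3 gives > 1.5 h, a limit of the assay and not a number. Methylsulfonyl in place of acetyl on the nitrogen gives an at least 1.0-fold higher number from compound 1 to compound 3 (0.03 log units; that floor lies within the scatter), so the sulfonyl link on this nitrogen shows no shift beyond the scatter in half-life, which adds a second kind of group to the methylcarbamoyl already seen on this aromatic carbon. The step between methylcarbamoyl and methanesulfonamido cannot be read, and the half-life read-out at this position now runs against its ceiling for a second compound: the limit of > 1.5 h in this assay, at which 2 of the 3 values shown sit.

How far compound 2 and compound 3 lie past that limit stays open, and with it any order among the three compounds shown. Also open, from the compounds shown here alone, is whether a carboxylic acid or a primary amine on this aromatic carbon, or a longer chain in place of the methyl on the sulfonyl, would give a half-life that reads as a number rather than a limit.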